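The source may hold more compounds than are shown below. What is called first, only, known or untested is meant among the compounds shown, and "the series" means these compounds.

Compound 2 `COc1ccc(OC)c(-c2cc(-c3ccc(C(=O)N(C)C)s3)on2)c1` carries dimethylamino on the carbonyl carbon that sits on the shared core. In a functional assay on A549 cells (Homo sapiens) for cytotoxicity, read by XTT assay, with a stated time of 72 h (on this read-out lower numbers stand for stronger inhibition and higher numbers for weaker inhibition), compound 2 gives > 30000 nM, which is a limit of the assay rather than a measured number. Compound 1 `COc1ccc(OC)c(-c2cc(-c3ccc(C(=O)N4CCCC4)s3)on2)c1` carries pyrrolidin-1-yl on that same carbonyl carbon. In this assay compound 1 gives > 30000 nM, again a limit. The step that the two limits leave unreadable from compound 1 to compound 2 is therefore of unreadable size. Compound 3 `COc1ccc(OC)c(-c2cc(-c3ccc(C(=O)NCC4CC4)s3)on2)c1` is the next member. The change from compound 2 to compound 3 is (cyclopropylmethyl)amino in place of dimethylamino on a carbonyl carbon, which one bond further out reads as dimethylcarbamoyl to (cyclopropylmethyl)carbamoyl. Among the measured compounds shown here, no measured step tells how much this exchange moves the read-out; the only guidance is the limit of > 30000 nM in this assay, at which 2 of the 2 values shown sit, so no shift beyond the scatter is expected in either direction. The expected step that the limit leaves unreadable from compound 2 to compound 3 reflects that. Compound 3 is estimated at 40000 nM, in a range from 15000 nM to 100000 nM, most likely reported once more as a limit.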

Compound 3, half-maximal inhibitory concentration: > 30000 nM
Compound 3 ended at the assay's limit; the forecaster's own chance of this, stated with the estimate: 80%; the middle value lies beyond the limit too.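

No step can be read from compound 1, compound 2 or compound 3, because all three results are limits rather than measured numbers: the limit of > 30000 nM in this assay, at which 3 of the 3 values shown sit.

The compounds shown leave open whether changing the group on the carbonyl carbon of the shared core shifts the read-out at all.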